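The compounds below may be only part of what the source reports. "The series", "measured", "known", "first", "only" and "open" are said of these compounds alone.

Measured so far in an ADME assay on HEK293 cells for inhibition of cytochrome P450 1A1 (Homo sapiens), with stated times of 30 min and 60 min, tested at 10 uM; a lower number here means less inhibition, a higher number more inhibition at the concentration tested (going by the name of the read-out):
compound 1 `COc1cc(-c2nc3ccccc3c(=O)[nH]2)ccc1OCc1ccc(Cl)cc1Cl` — 36.6%
compound 2 `C#CCOc1cc(-c2nc3ccccc3c(=O)[nH]2)ccc1OC` — 65.9%
compound 3 `O=c1[nH]c(-c2ccc(OS(=O)(=O)c3ccccc3)cc2)nc2ccccc12` — 22.9%

Among these three numbers, compound 1 stands second highest. Its nearest neighbour is compound 3, whose inhibition lies beyond the scatter below that of compound 1; the furthest is compound 2, whose inhibition lies beyond the scatter above it. All three share the same core, and they differ only in what hangs from the phenyl ring, so the three values give a spread without any single-change pair to lean on.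

The step of interest leads from compound 1 to compound 4 `COc1cc(-c2nc3ccccc3c(=O)[nH]2)ccc1OCc1ccc(F)cc1`, which has not yet been measured in this assay. The change is 4-fluorophenyl in place of 2,4-dichlorophenyl on a saturated chain carbon bound to an oxygen on an aromatic ring. Within the data shown here, no pair of measured compounds differs by a single change, so there is no directly comparable step to quote. On the basis of the spread seen across compounds 1, 2 and 3, a modest step is expected, with the direction uncertain and possibly no step beyond the scatter. Compound 4 is therefore expected to give about 34%, within a range from 15% to 55%. The expected step of a number 2.6 percentage points lower from compound 1 to compound 4 (within the scatter) is estimated to be small.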

Compound 4, a percentage reported as inhibition, at one concentration (the size of the read-out at that concentration, not a potency): 11.8%
Estimate against measurement, compound 4: 22.2 percentage points above; the whole stated range lies above it.
By their numbers in this assay, from the lowest: compound 4; then compound 3; then compound 1; then compound 2.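

In this assay, among these compounds, 4-fluorophenyl in place of 2,4-dichlorophenyl on a saturated chain carbon bound to an oxygen on an aromatic ring gives a number 24.8 percentage points lower from compound 1 to compound 4 (beyond the scatter), the first single-change step, and it shows that the read-out responds to the aryl group at this place while the rest of the molecule stays the same. The change alters the halogens in two ways at once, so this one step cannot divide its size between the loss of a chlorine and the arrival of fluorine. No measurement shown offers an explanation for the step.

Open, as far as these compounds go, is how a 4-chlorophenyl or an unsubstituted phenyl group would read at this place. Also open, from the compounds shown here alone, is whether a carboxylic acid or an amine on the benzyl ring, or a longer chain to the ring, would shift the inhibition further.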